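This account rests on a few compounds, and the source may have more. Where it says the series, first, only, none or still open, it means among the compounds named here.

Of the compounds shown here, three built on one shared core have been tested in an assay on isolated protein for inhibition of DNA topoisomerase 1 (Homo sapiens), with a stated time of 30 min, tested at 100 uM; on this read-out higher numbers stand for a stronger effect at the one concentration tested and lower numbers for a weaker effect. Compound 1 `Oc1ccc(-c2cc(-c3ccc(Cl)cc3)nc(-c3cccnc3)c2)cc1` gives 18.8%, compound 2 `Oc1ccc(-c2cc(-c3ccc(Cl)cc3)nc(-c3cccs3)c2)cc1` gives 38.8%, and compound 3 `Oc1cccc(-c2cc(-c3ccccc3)nc(-c3ccc(Cl)cc3)c2)c1` gives 7.1%, the lowest of the three. Among the measured compounds shown here, the only measured step, a number 20 percentage points higher from compound 1 to compound 2 (beyond the scatter), concerns another part of the core and says nothing about the hydroxyphenyl group. Compound 4 `Oc1ccc(-c2cc(-c3ccccc3)nc(-c3ccc(Cl)cc3)c2)cc1` differs from compound 3 in one place: 4-hydroxyphenyl in place of 3-hydroxyphenyl on an aromatic carbon. For the measured compounds named here, no measured step covers this move. Compounds 1 and 2 both carry 4-hydroxyphenyl and both sit higher than compound 3, yet they differ from it elsewhere too, so this is only a loose hint. Compound 4 is therefore expected to show a small rise, a number 9.9 percentage points higher from compound 3 to compound 4 (within the scatter). The estimate for compound 4 in this assay is 17%, with a range from 4% to 34%.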

Compound 4, a percentage reported as inhibition, at one concentration (the size of the read-out at that concentration, not a potency): 68%
Compound 4: the middle estimate sits 51 percentage points below what was measured, and the stated range ends below it.
By their numbers in this assay, from the lowest: compound 3; then compound 1; then compound 2; then compound 4.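

In this assay, the step of a number 60.9 percentage points higher from compound 3 to compound 4 (beyond the scatter) shows that the same atoms, rearranged as 4-hydroxyphenyl rather than 3-hydroxyphenyl on the carbon opposite the ring nitrogen, can change the read-out strongly. The neighbouring aryl group matters too: phenyl gives a number 29.2 percentage points higher from compound 2 to compound 4 (beyond the scatter) and a number 49.2 percentage points higher from compound 1 to compound 4 (beyond the scatter), placing it above both thiophen-2-yl and pyridin-3-yl in this series. Nothing available explains these differences. Still open, from the compounds shown here alone, is whether the hydroxyl itself is needed, or whether 4-methoxyphenyl or 4-aminophenyl would serve equally well. Going by these compounds, whether the phenyl gain holds with 3-hydroxyphenyl also remains unknown.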